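Chain ether in place of propyl on a low-stability scaffold

This account rests on a few compounds, and the source may have more. Where it says the series, first, only, none or still open, it means among the compounds named here.

Compound 1 `CCCCc1nc(=O)c(S(=O)(=O)c2ccc(-c3cccnc3)cc2)c(O)n1-c1c(OC)cccc1OC`: 3%
Compound 2 `CCCCc1nc(=O)c(S(=O)(=O)c2ccc(-c3ccc(F)nc3)cc2)c(O)n1-c1c(OC)cccc1OC`: 2%
Compound 3 `CCCCc1nc(=O)c(S(=O)(=O)c2ccc(-n3cc(Cl)ccc3=O)cc2)c(O)n1-c1c(OC)cccc1OC`: 74%

In an ADME assay on microsomes from liver (Rattus norvegicus) for metabolic stability, using NADPH, with a stated time of 10 min (a lower number here means that less of the compound is left, a higher number that more of the compound is left), compound 2 gives the lowest of the three numbers, though the gap is small a number 1 percentage points lower from compound 1 to compound 2 (within the scatter) and only compound 3 stands apart from it a number 72 percentage points higher from compound 2 to compound 3 (beyond the scatter). Compound 4 `COc1cccc(OC)c1-n1c(COC(C)C)nc(=O)c(S(=O)(=O)c2ccc(-c3ccc(F)nc3)cc2)c1O` keeps the fluorinated ring of compound 2 and alters only the chain on the shared core: isopropoxy in place of propyl on a saturated chain carbon bound to an aromatic carbon. Within the data shown here, none of the measured steps touches this chain. The step from compound 1 to compound 2 concerns the fluoro substituent and lies within the scatter. The two steps ending at compound 3 concern the distal ring and say nothing about the chain, though both are large, as in a number 71 percentage points higher from compound 1 to compound 3 (beyond the scatter). Among the measured compounds shown here, with no step bearing on the change, the expectation rests on compound 2 alone, whose value of 2% leaves little room downward, so compound 4 is expected to show a number 6 percentage points higher from compound 2 to compound 4 (within the scatter) in this assay. Compound 4 is therefore estimated at 8%, within 1% to 35%.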

Compound 4, percent of the compound remaining: 30%
For compound 4 the middle estimate is 22 percentage points below the measured one; the measured number falls inside the stated range.
By their numbers in this assay, from the lowest: compounds 2 and 1 (each within the scatter of the next); then compound 4; then compound 3.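

In this assay, the chain on the shared core proves to count: a number 28 percentage points higher from compound 2 to compound 4 (beyond the scatter), with isopropoxy in place of propyl on a saturated chain carbon bound to an aromatic carbon. The earlier steps shown here changed only other parts of the molecule, so they could not show that this position moves the number beyond the scatter, though this step is smaller than a number 72 percentage points higher from compound 2 to compound 3 (beyond the scatter). Nothing at hand gives a reason for the rise in compound 4.

The compounds shown leave open whether the rise belongs to the chain oxygen or to the branched isopropyl end, a question that a methoxy or a straight propoxy group at this place could separate. They also leave open how an amine in this chain would read.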